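A Longer Saturated Chain on a Shared Core

A few compounds are considered here, and "the series" means these few. Any claim that something is new, unique, unknown or untested is made for them only; others in the source may bear on it.

Of the compounds shown here, three with the same core have been tested in a functional assay on MCF7 cells (Homo sapiens) for inhibition; a lower number here means a stronger inhibitor, a higher number a weaker inhibitor. There, compound 1 `C/C=C/C(C)=C/[C@@]1(C)SC(O)=CC1=O` gives 17.3 ug/mL, compound 2 `CC/C=C/C=C/[C@@]1(C)SC(O)=CC1=O` gives 16.9 ug/mL, and compound 3 `CCCCCC[C@@]1(C)SC(O)=CC1=O` gives 16.5 ug/mL. Compound 3 therefore stands level with the other two, since all three numbers lie within the usual scatter of repeated measurements, even though the chains on the core differ.

Compound 4 `CCCCCCCC[C@@]1(C)SC(O)=CC1=O` has not yet been measured. It differs from compound 3 by ethyl in place of hydrogen on a saturated chain carbon, six bonds along the chain from a saturated ring carbon, which means ethyl in place of hydrogen on a saturated chain carbon, six bonds along the chain from a saturated ring carbon. Going by the values given here, no measured pair of compounds isolates this change, so the evidence for it is indirect. Among the compounds with values here, the only guide is that compound 1 at 17.3 ug/mL and compound 2 at 16.9 ug/mL sit level with compound 3 at 16.5 ug/mL. In this assay, the expected step of a 1.0-fold lower number from compound 3 to compound 4 (0.01 log units; within the scatter) is none beyond the scatter. For compound 4, the estimated value is 16 ug/mL, with an expected range from 8 ug/mL to 30 ug/mL.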

Compound 4, half-maximal inhibitory concentration: 12.6 ug/mL
Estimate against measurement, compound 4: 1.3-fold (0.10 log units) above, within the range that was stated.
By their numbers in this assay, from the lowest: compounds 4, 3, 2 and 1 (each within the scatter of the next).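

In this assay ethyl in place of hydrogen on a saturated chain carbon, six bonds along the chain from a saturated ring carbon, gives a 1.3-fold lower number from compound 3 to compound 4 (0.12 log units; within the scatter) and so makes no difference that can be told from the scatter. Going by these compounds alone, this is the first comparison here of two compounds that differ in one place, and it shows that this position accepts the extra ethyl with the number staying level. Nothing available here explains this result.

A single step at one position cannot show whether the numbers stay level for a chain longer than that of compound 4. It also leaves open what happens when the chain ends in a different group, such as an amine or a carboxylic acid.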